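Azo naphthol series: carboxyphenyl for trifluoromethylphenyl on the ring nitrogen

A few compounds are considered here, and "the series" means these few. Any claim that something is new, unique, unknown or untested is made for them only; others in the source may bear on it.

Compound 1 `O=S(=O)(O)c1ccc(/N=N/c2c(O)ccc3ccccc23)c2ccccc12` and compound 2 `Cc1[nH]n(-c2cccc(C(F)(F)F)c2)c(=O)c1/N=N/c1c(O)cc(S(=O)(=O)O)c2ccccc12` share the azo-linked naphthol core. In an assay on BaF3 cells with thrombopoietin receptor (Homo sapiens) as the target, read by a luciferase reporter (a lower number here means a smaller maximal response, a higher number a larger maximal response), compound 1 gives < 5%, which is a limit of the assay and not a number. In this assay compound 2 gives 62%. Going by the values given here, of the two values shown, compound 2 holds the only number, while the other sits at the limit of < 5% in this assay, at which 1 of the 2 values shown sits. Among the compounds with values here, no step between measured compounds that differ in one place is available, so the series offers no measured guide for a change on the aromatic nitrogen.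

Compound 3 `Cc1[nH]n(-c2ccc(C(=O)O)cc2)c(=O)c1/N=N/c1c(O)cc(S(=O)(=O)O)c2ccccc12` is not yet measured in this assay. It differs from compound 2 in this way: 4-carboxyphenyl in place of 3-(trifluoromethyl)phenyl on an aromatic nitrogen. The change is 4-carboxyphenyl in place of 3-(trifluoromethyl)phenyl on an aromatic nitrogen of the five-membered aromatic ring with 2 nitrogen.

Without a measured step of this kind, a moderate downward step in this assay is expected, a number 22 percentage points lower from compound 2 to compound 3 (beyond the scatter), somewhat beyond the scatter, with wide uncertainty. Compound 3 is expected to give 40%, estimated between 5% and 75%.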

Compound 3, largest response reached (reported as efficacy), in percent of the reference or control that the assay uses: < 5%
Compound 3: a limit, no number; the forecaster's own chance of this, stated with the estimate: 25%; middle value at least 35 percentage points from the limit.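

In this assay the group on the aromatic nitrogen now has its first measured step: 4-carboxyphenyl in place of 3-(trifluoromethyl)phenyl gives a number at least 57 percentage points lower from compound 2 to compound 3 (beyond the scatter). Compound 2 and compound 3 differ in this one place only, so the response seen for compound 2 depends on the group at this position and is not carried by the rest of the structure alone. The step has only a lower bound, because the value of compound 3 is a limit of the assay and not a number: the limit of < 5% in this assay, at which 2 of the 3 values shown sit.

The two groups differ both in their substituent and in where it stands on the phenyl ring, so the compounds shown do not separate the arrival of the carboxylic acid, the departure of the trifluoromethyl group and the change of place on the ring. Also open, on these data alone, is whether a methyl ester in place of the carboxylic acid, or a chlorine or an amine on the same phenyl ring, would keep any of the response of compound 2.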